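Trimming the Alkyne Terminus of Compound 1

The source may report more compounds than this note shows. Statements on the series, on what has been measured and on what is new or still open speak of the compounds shown alone.

Compound 1 `CC[Si](C#Cc1ccc2c(c1)C=C([N+](=O)[O-])C(C(F)(F)F)O2)(CC)CC`: 604 nM
Compound 2 `COC(=O)[C@H](C)NC(=O)c1ccc(C#Cc2ccc3c(c2)C=C([N+](=O)[O-])C(C(F)(F)F)O3)cc1`: 6840 nM
Compound 3 `O=C1c2ccccc2C(=O)N1CC#Cc1ccc2c(c1)C=C([N+](=O)[O-])C(C(F)(F)F)O2`: 4650 nM

Of the compounds shown here, three sharing one core have been tested in a functional assay on 1321N1 cells for antagonist activity at P2Y purinoceptor 6 (Homo sapiens), read by fluorescence and calcium flux; a higher number here means a weaker inhibitor, a lower number a stronger inhibitor. Compound 1 gives 604 nM, the lowest number of the three; compound 3 gives 4650 nM and compound 2 gives 6840 nM, both beyond the scatter from compound 1. Compound 4 `O=[N+]([O-])C1=Cc2cc(C#CC3CC3)ccc2OC1C(F)(F)F` has not yet been measured. It differs from compound 1 in one place: a group of 3 heavy atoms (3 carbon; one three-membered non-aromatic ring of carbon only) in place of a group of 7 heavy atoms (6 carbon, 1 silicon; no ring), on a triple-bonded carbon. Within the data shown here, no measured step isolates this kind of change, so compound 1 is the only anchor and the direction is uncertain. The expected change is a 2.5-fold higher number from compound 1 to compound 4 (0.40 log units; beyond the scatter), a modest loss that may barely clear the scatter. Compound 4 is estimated at 1500 nM, within a range from 400 nM to 6000 nM.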

Compound 4, half-maximal inhibitory concentration: 4870 nM
For compound 4 the middle estimate is 3.2-fold (0.51 log units) below the measured one; measured number inside the range.
By their numbers in this assay, from the lowest: compound 1; then compounds 3, 4 and 2 (each within the scatter of the next).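

On the triple-bonded carbon, cyclopropyl in place of the group of 7 heavy atoms gives an 8.1-fold higher number from compound 1 to compound 4 (0.91 log units; beyond the scatter) in this assay. Among these compounds, this is the first change at this position confined to one place, and it shows that the terminal group matters to the number: the smaller carbon ring does not hold the level of compound 1. Nothing available explains this loss. From the compounds shown here alone, whether the silicon, the ring or the count of heavy atoms decides the outcome stays open. A tert-butyl group or a longer alkyl chain on the same carbon would help separate these.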